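This account rests on a few compounds, and the source may have more. Where it says the series, first, only, none or still open, it means among the compounds named here.

Working notes on the series. Compound 1 `O=C1CCCCC/C1=C\c1cccc(F)c1` gives > 50000 nM in a functional assay on P388 cells (Mus musculus) for inhibition (on this read-out lower numbers stand for stronger inhibition and higher numbers for weaker inhibition), which is a limit of the assay and not a number. Among the compounds with values here, compound 2 `COc1cccc(/C=C2\CCCCCC2=O)c1` gives 50000 nM in this assay, the only true number so far, so it cannot yet be ranked against a second number. Within the data shown here, the one measured step is a number no higher from compound 1 to compound 2 (the limit leaves the size open), with methoxy in place of fluoro on an aromatic carbon. The evidence is thin: the limit of > 50000 nM in this assay, at which 1 of the 2 values shown sits.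

Compound 3 `O=C1CCCCC/C1=C\c1cccc([N+](=O)[O-])c1` differs from compound 2 by nitro in place of methoxy on an aromatic carbon, meta to a group of 9 heavy atoms. The fluoro-to-methoxy step, a number no higher from compound 1 to compound 2 (the limit leaves the size open), gives no usable size and involves a different incoming group, so no step beyond the scatter is expected in this assay, and another limit reading would not be surprising. The expected step is a 1.1-fold lower number from compound 2 to compound 3 (0.05 log units; within the scatter). For compound 3 the estimated value is 45000 nM, with an expected range of 15000 nM to 60000 nM.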

Compound 3, half-maximal inhibitory concentration: 23600 nM
The estimate for compound 3 lay 1.9-fold (0.28 log units) above the measured number; the measured number falls inside the stated range.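

Within the data shown here, with compound 3, this place on the aromatic ring gives the first step of readable size in this assay: there is a 2.1-fold lower number from compound 2 to compound 3 (0.33 log units; beyond the scatter), where nitro enters in place of methoxy, meta to a group of 9 heavy atoms. Set against the fluoro compound, the same group gives an at least 2.1-fold lower number from compound 1 to compound 3 (0.32 log units; beyond the scatter), so the choice of group at this one place does shift the number, by a modest amount among the three compounds shown. Compound 1 stands at a limit and not a number, which leaves the size of that second step open on one side: the limit of > 50000 nM in this assay, at which 1 of the 3 values shown sits.

Among these compounds, whether an amine or a carboxylic acid at this place would continue the shift, or give no step at all, stays open, as does whether nitro would give a step of like size on another carbon of the aromatic ring. The three compounds also differ only at this one place, so they say nothing about how a change to the shared core, such as a longer chain on it, would move the number in this assay.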